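The source may report more compounds than this note shows. Statements on the series, on what has been measured and on what is new or still open speak of the compounds shown alone.

Measured compounds in a functional assay on T-24 cells (Homo sapiens) for antiproliferative activity, read by MTT assay, with a stated time of 48 h; on this read-out lower numbers stand for stronger inhibition and higher numbers for weaker inhibition:
- compound 1, `Cc1ccc(NC(=O)Nc2cccc(CNc3nccnc3Cl)c2)cc1Cl`: 7390 nM
- compound 2, `O=C(Nc1cccc(CNc2nccnc2Cl)c1)Nc1ccc(Cl)cc1Br`: 6650 nM
- compound 3, `Cc1ccc(NC(=O)Nc2cccc(CNc3nccnc3Cl)c2)c(C)c1`: 9230 nM

All three numbers lie within the scatter of one another; compound 3 gives the numerically largest value, with a 1.2-fold higher number from compound 1 to compound 3 (0.10 log units; within the scatter) and a 1.4-fold higher number from compound 2 to compound 3 (0.14 log units; within the scatter) both inside the scatter. Compound 4, `O=C(Nc1cccc(CNc2nccnc2Cl)c1)Nc1ccc(Cl)c(Cl)c1`, differs from compound 3 by 3,4-dichlorophenyl in place of 2,4-dimethylphenyl on an amide-type nitrogen. Going by the values given here, the steps that bear on this are the two earlier exchanges of the aryl group on the same amide-type nitrogen, a 1.2-fold higher number from compound 1 to compound 3 (0.10 log units; within the scatter) and a 1.4-fold higher number from compound 2 to compound 3 (0.14 log units; within the scatter), neither of which moved the number beyond the scatter, and a 1.1-fold lower number from compound 1 to compound 2 (0.05 log units; within the scatter) likewise. No shift beyond the scatter is therefore expected in this assay, in either direction. Compound 4 is estimated at 7500 nM, with a range of 3500 nM to 16000 nM. The expected step from compound 3 is a 1.2-fold lower number from compound 3 to compound 4 (0.09 log units; within the scatter).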

Compound 4, half-maximal inhibitory concentration: 5210 nM
Beside the measured number, compound 4's estimate is 1.4-fold (0.16 log units) above it, within the range that was stated.
By their numbers in this assay, from the lowest: compounds 4, 2, 1 and 3 (each within the scatter of the next).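

In this assay, 3,4-dichlorophenyl joins the other aryl groups on the amide-type nitrogen that leave the number inside the scatter, with a 1.8-fold lower number from compound 3 to compound 4 (0.25 log units; within the scatter) and a 1.3-fold lower number from compound 2 to compound 4 (0.11 log units; within the scatter). The exchange of chloro for methyl on an aromatic carbon, the smallest change in the series, also stays inside the scatter, with a 1.4-fold lower number from compound 1 to compound 4 (0.15 log units; within the scatter). No measurement at hand accounts for how closely these numbers sit.

From the compounds shown here alone, whether an amine or a carboxylic acid on this aryl ring would shift the number beyond the scatter remains open. So does the outcome of changes to the shared core.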